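Methyl on the sulfonyl ring of a compound at the limit

This account rests on a few compounds, and the source may have more. Where it says the series, first, only, none or still open, it means among the compounds named here.

Compound 2 `COc1cc(Nc2nc3ccccc3nc2S(=O)(=O)c2ccccc2)cc(OC)c1OC` stands apart from the two compounds measured beside it. In a functional assay on HCT-116 cells (Homo sapiens) for cytotoxicity, read by MTT assay, with a stated time of 72 h (a lower number here means a stronger inhibitor, a higher number a weaker inhibitor), compound 2 reaches only the limit of the assay, > 50000 nM. Compound 1 `COc1cc(Nc2nc3ccccc3nc2S(=O)(=O)c2ccccc2)cc(OC)c1` gives 950 nM in this assay, and compound 3 `Nc1cccc(Nc2nc3ccccc3nc2S(=O)(=O)c2ccccc2)c1` gives 1540 nM. The step of an at least 52-fold higher number from compound 1 to compound 2 (1.72 log units; beyond the scatter) is therefore the only large one seen, while the step of a 1.6-fold higher number from compound 1 to compound 3 (0.21 log units; within the scatter) falls inside the usual scatter; compound 2 sits at the limit of > 50000 nM in this assay, at which 1 of the 3 values shown sits.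

Compound 4 `COc1cc(Nc2nc3ccccc3nc2S(=O)(=O)c2ccc(C)cc2)cc(OC)c1OC` differs from compound 2 by methyl in place of hydrogen on an aromatic carbon, a change on the phenylsulfonyl part rather than on the anilino part that the two measured steps probe. Among the measured compounds shown here, no measured step touches that ring, so no step beyond the scatter is expected from the methyl. Because compound 2 already sits at the limit of > 50000 nM in this assay, at which 1 of the 3 values shown sits, compound 4 is expected to remain at or near that limit, with the step of a number no higher from compound 2 to compound 4 (the limit leaves the size open) expected to stay within the scatter. For compound 4 the estimate in this assay is 50000 nM, within 12000 nM to 200000 nM.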

Compound 4, half-maximal inhibitory concentration: 10800 nM
Beside the measured number, compound 4's estimate is 4.6-fold (0.67 log units) above it, outside the stated range (below it).
By their numbers in this assay, from the lowest: compounds 1 and 3 (each within the scatter of the next); then compound 4. At a limit, above all of these: compound 2.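

Going from phenylsulfonyl to (4-methylphenyl)sulfonyl gives an at least 4.6-fold lower number from compound 2 to compound 4 (0.66 log units; beyond the scatter), the only measured change shown on this ring, so a single methyl on an aromatic carbon, para to a large group, moves the number in this assay beyond the scatter. Compound 2 stands at a limit of the assay, > 50000 nM, and that value is not a number. The full size of the step therefore stays open, because one end of it is only a limit: the limit of > 50000 nM in this assay, at which 1 of the 4 values shown sits.

From the compounds shown here alone, whether the same methyl would change the number on compound 1 or compound 3, whose values are not at a limit, remains open. Also open, going by these compounds, is how a chlorine, a methoxy, an amine or a longer chain such as ethyl would read at this same place on the ring.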